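The compounds below may be only part of what the source reports. "The series", "measured", "known", "first", "only" and "open" are said of these compounds alone.

In a functional assay on A549 cells (Homo sapiens) for inhibition, read by MTT assay, with a stated time of 48 h (on this read-out lower numbers stand for stronger inhibition and higher numbers for weaker inhibition), compound 1 `COc1ccc(N(C)c2nc(C)nc3ccccc23)cc1C(=O)OCCC[Se]C#N` gives 250 nM and compound 2 `COc1ccc(N(C)c2nc(C)nc3ccccc23)cc1C(=O)NCC[Se]C#N` gives 187 nM, which amounts to a 1.3-fold lower number from compound 1 to compound 2 (0.13 log units; within the scatter). Compound 3 `COc1ccc(N(C)c2nc(C)nc3ccccc23)cc1[Se]C` gives 11 nM, the lowest number of the three. Compound 4 `COc1ccc(N(C)c2nc(C)nc3ccccc23)cc1OCCCC[Se]C#N` has not yet been measured. It differs from compound 3 by a group of 8 heavy atoms (5 carbon, 1 nitrogen, 1 oxygen, 1 selenium; no ring) in place of a group of 2 heavy atoms (1 carbon, 1 selenium; no ring), on an aromatic carbon.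

Among the compounds with values here, two measured steps bear on this change: a 23-fold lower number from compound 1 to compound 3 (1.36 log units; beyond the scatter) and a 17-fold lower number from compound 2 to compound 3 (1.23 log units; beyond the scatter). Compound 1 and compound 2 resemble compound 4 in carrying a chain that ends in selenium and nitrile, but their chains are attached through a carbonyl. Within the data shown here, compound 4 has an oxygen link instead, and no measured compound shows what that link does. Read in reverse, the two steps point to a large move towards a higher number in this assay, though with some uncertainty. The expected result is a 15-fold higher number from compound 3 to compound 4 (1.19 log units; beyond the scatter). For compound 4, the estimated value is 170 nM, with an expected range from 50 nM to 550 nM.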

Compound 4, half-maximal inhibitory concentration: 1200 nM
Estimate against measurement, compound 4: 7.1-fold (0.85 log units) below; the measured number lies above the stated range.
By their numbers in this assay, from the lowest: compound 3; then compounds 2 and 1 (each within the scatter of the next); then compound 4.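

In this assay, within the data shown here, this position, ortho to a methoxy group, proves far more sensitive than the earlier compounds suggested: a 110-fold higher number from compound 3 to compound 4 (2.04 log units; beyond the scatter), the largest step in the set. The chain attached through oxygen also separates from the two chains attached through a carbonyl, with a 6.4-fold higher number from compound 2 to compound 4 (0.81 log units; beyond the scatter) and a 4.8-fold higher number from compound 1 to compound 4 (0.68 log units; beyond the scatter), both beyond the scatter. The shared selenium and nitrile chain end therefore does not alone set the number at this position, although these chains differ in more than the link, so the oxygen link cannot be isolated as the deciding feature.

Nothing available explains the higher number of compound 4. On these data alone, it remains open how a shorter oxygen-linked chain or an amine link would read, and whether a methylthio group could replace the small selenium group of compound 3.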